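Swapping a pyridine for a thiadiazole on a stable scaffold

A few compounds are considered here, and "the series" means these few. Any claim that something is new, unique, unknown or untested is made for them only; others in the source may bear on it.

Measured so far:
Compound 1 `CC(C)n1nc(Cn2c(=O)c3ccccc3n2CCCCO)c2ccccc21` — 462 mL.min-1.g-1
Compound 2 `O=c1n(Cc2nc(-c3cccnc3)cn2CCCCO)c2cnccc2n1C1CC1` — < 8 mL.min-1.g-1

Of the compounds shown here, two have been tested in an ADME assay on microsomes from liver (Homo sapiens) for metabolic stability; on this read-out lower numbers stand for slow clearance and higher numbers for fast clearance. Compound 1 `CC(C)n1nc(Cn2c(=O)c3ccccc3n2CCCCO)c2ccccc21` gives 462 mL.min-1.g-1 in this assay, a fast-clearance result. Compound 2 `O=c1n(Cc2nc(-c3cccnc3)cn2CCCCO)c2cnccc2n1C1CC1` is reported only as a limit of this assay, < 8 mL.min-1.g-1, so its true number is not known, only that it lies at the floor of what this assay can report (the limit of < 8 mL.min-1.g-1 in this assay, at which 1 of the 2 values shown sits). The two compounds share no single-point difference, so their values are simply two points on the scale, one high and one at the limit.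

Compound 3 `Cc1nnc(-c2cn(CCCCO)c(Cn3c(=O)n(C4CC4)c4ccncc43)n2)s1` differs from compound 2 in one place: 5-methyl-1,3,4-thiadiazol-2-yl in place of pyridin-3-yl on an aromatic carbon. Both the leaving and the entering groups have the same number of heavy atoms, and the rest of the molecule is unchanged.

For the measured compounds named here, with no measured step to lean on, the expectation for this assay is a change no larger than the usual scatter, or at most a small rise in clearance. Compound 3 is therefore expected to give about 10 mL.min-1.g-1, within the range 4 mL.min-1.g-1 to 30 mL.min-1.g-1, which would mean an estimated step of an at least 1.2-fold higher number from compound 2 to compound 3 (0.09 log units; that floor lies within the scatter).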

Compound 3, intrinsic clearance in microsomes: < 8 mL.min-1.g-1
Compound 3: only a limit was reported; the forecaster's own chance of this, stated with the estimate: 40%; middle value at least 1.2-fold (0.09 log units) from the limit.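

In this assay compound 3 gives < 8 mL.min-1.g-1, which is a limit of the assay and not a number. No step from compound 2 to compound 3 can be read, because both compounds stop at the same limit: the limit of < 8 mL.min-1.g-1 in this assay, at which 2 of the 3 values shown sit.

The compounds shown leave open whether 5-methyl-1,3,4-thiadiazol-2-yl in place of pyridin-3-yl changes the true clearance at all, and in which direction.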